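The compounds below may be only part of what the source reports. "The series", "measured", "known", "first", "only" and "open" are said of these compounds alone.

In a functional assay on KB cells (Homo sapiens) for cytotoxicity, read by resazurin assay, with a stated time of 3 days (on this read-out higher numbers stand for weaker inhibition and lower numbers for stronger inhibition), compound 1 `CCCC(C)C(=O)NCC(C)(C)CC1=C(O)C(=O)c2ccccc2C1=O` gives 47100 nM and compound 2 `CCCCCC(=O)NCC(C)(C)CC1=C(O)C(=O)c2ccccc2C1=O` gives 40200 nM. Among the compounds with values here, compound 2 therefore stands within the scatter of the only other measured compound, and neither can be ranked above the other. Compound 3 `CCCCCCCC(=O)NCC(C)(C)CC1=C(O)C(=O)c2ccccc2C1=O` differs from compound 2 by ethyl in place of hydrogen on a saturated chain carbon, five bonds along the chain from a carbonyl carbon. The same change can be read as propyl to pentyl, on the chain attached to the carbonyl carbon. Within the data shown here, only one measured step bears on this chain, a 1.2-fold lower number from compound 1 to compound 2 (0.07 log units; within the scatter), and it exchanges one chain for another rather than extending it. The data contain no measured extension of the chain, so the guidance is weak. A small shift towards a lower number in this assay is expected, with nothing beyond the scatter. The expected step is a 1.3-fold lower number from compound 2 to compound 3 (0.13 log units; within the scatter). For compound 3 the estimated value is 30000 nM, with an expected range of 12000 nM to 60000 nM.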

Compound 3, half-maximal inhibitory concentration: 24600 nM
Estimate against measurement, compound 3: 1.2-fold (0.09 log units) above, within the range that was stated.
By their numbers in this assay, from the lowest: compounds 3, 2 and 1 (each within the scatter of the next).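

Ethyl in place of hydrogen at this place, five bonds along the chain from a carbonyl carbon, is the first real extension of the chain in the series: a 1.6-fold lower number from compound 2 to compound 3 (0.21 log units; within the scatter) in this assay. The comparison with the branched chain gives a 1.9-fold lower number from compound 1 to compound 3 (0.28 log units; within the scatter), so neither lengthening the chain nor exchanging the branched chain for heptyl produces a step beyond the scatter in these compounds. Nothing measured here speaks to the origin of these small steps.

As far as these compounds go, whether a chain longer than heptyl would give a step beyond the scatter remains open. Also open, from the compounds shown here alone, is how an amine or a carboxylic acid on this chain would read in this assay, with the shared core kept.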